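A few compounds are considered here, and "the series" means these few. Any claim that something is new, unique, unknown or untested is made for them only; others in the source may bear on it.

Working notes on the series, read out in a physicochemical assay for lipophilicity, using the shake flask method, in phosphate buffer, measured as octanol-water partition, at pH 7.4; on this read-out higher numbers stand for higher lipophilicity and lower numbers for lower lipophilicity. Compound 1 (`CC[C@@H](c1ccc(C(=O)O)c(Oc2cccc(Cl)c2)c1F)N1CCC[C@H](n2cc(C)c(=O)[nH]c2=O)C1`) gives 0.11 and compound 2 (`CC[C@H](c1ccc(C(=O)O)c(Oc2cccc(Cl)c2)c1OC)N1CCC[C@H](n2cc(C)c(=O)[nH]c2=O)C1`) gives -0.13, two values within the scatter of each other. Compound 3 (`Cc1cn([C@H]2CCCN([C@H](CC(C)C)c3ccc(C(=O)O)c(Oc4cccc(Cl)c4)c3F)C2)c(=O)[nH]c1=O`) gives 0.92, the highest of the three and beyond the scatter from both of the others. Compound 4 (`CC[C@H](c1ccc(C(=O)O)c(Oc2cccc(Cl)c2)c1F)N1CCC[C@H](n2cc(C)c(=O)[nH]c2=O)C1`) has no value yet. Its difference from compound 3 is methyl in place of isopropyl on a saturated chain carbon, two bonds along the chain from an amine nitrogen in a ring and an aromatic carbon. Cut one bond further out, this reads isobutyl to ethyl. Among the compounds with values here, no measured pair isolates this change, so the expectation is indirect. Compound 1 and compound 2 both carry the ethyl chain, and both read well under compound 3. The nearest in structure to compound 4 is compound 1, which stands at 0.11. In this assay a downward move beyond the scatter is expected, estimated as a number 0.72 log units lower from compound 3 to compound 4 (beyond the scatter). The estimate for compound 4 is 0.2, with an expected range from -0.2 to 0.6.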

Compound 4, distribution coefficient: 0.12
Compound 4: the middle estimate sits 0.08 log units above what was measured; low and high end bracket the measured number.
By their numbers in this assay, from the lowest: compounds 2, 1 and 4 (each within the scatter of the next); then compound 3.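

In this assay, methyl in place of isopropyl on a saturated chain carbon, two bonds along the chain from an amine nitrogen in a ring and an aromatic carbon, now has a matched pair behind it: a number 0.80 log units lower from compound 3 to compound 4 (beyond the scatter). The stereocentre at the saturated chain carbon gives no separation on this read-out, a number 0.01 log units higher from compound 1 to compound 4 (within the scatter), and this pair tests that stereocentre alone: the fact that compounds 1 and 4 differ only in the configuration as drawn. Fluoro in place of methoxy on an aromatic carbon also stays inside the scatter: a number 0.25 log units higher from compound 2 to compound 4 (within the scatter).

The compounds shown leave open where a propyl chain would fall relative to the ethyl and isobutyl compounds, and whether the isobutyl compound would also show no separation between its two configurations. Also open, going by these compounds, is whether a chloro or a hydroxyl on the aromatic carbon that holds fluoro or methoxy would stay within the scatter.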